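Fluoro on the Phenyl Ring: Cytotoxicity in RD Cells

The source may hold more compounds than are shown below. What is called first, only, known or untested is meant among the compounds shown, and "the series" means these compounds.

Compound 1 `Fc1ccc(-c2ccc3ncc(-c4noc(C(F)(F)F)n4)cc3c2)cc1` gives > 7400 nM in a functional assay on RD cells (Homo sapiens) for inhibition, read by luminescence and ATP content, with a stated time of 72 h (on this read-out lower numbers stand for higher toxicity in this test and higher numbers for lower toxicity in this test), a limit of the assay.
Compound 2 `CCc1nc(-c2cnc3ccc(-c4ccccc4)cc3c2)no1` gives > 7400 nM in this assay, a limit of the assay.

Compound 2 stands at a limit in this assay, > 7400 nM, so no number is known for it. Compound 1 likewise reports only a limit, > 7400 nM. Within the data shown here, both values therefore share (the limit of > 7400 nM in this assay, at which 2 of the 2 values shown sit), and no measured step between them can be drawn.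

Compound 3 `CCc1nc(-c2cnc3ccc(-c4ccc(F)cc4)cc3c2)no1` differs from compound 2 by fluoro in place of hydrogen on an aromatic carbon. Among the measured compounds shown here, no measured pair shows what this change does in this assay, and because compound 2 already sits at the limit of > 7400 nM in this assay, at which 2 of the 2 values shown sit, there is little room for a lower-toxicity reading to be seen. The step from compound 2 to compound 3 is expected to be none beyond the scatter, a step that the limit leaves unreadable from compound 2 to compound 3. Compound 3 is thus estimated to give 10000 nM in this assay, within 4000 nM to 30000 nM, and most probably again only a limit rather than a number.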

Compound 3, half-maximal cytotoxic concentration: > 7400 nM
Compound 3: no number, only a limit; the forecaster's own chance of this, stated with the estimate: 85%; the middle value is on the limit's open side.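

Compound 3 gives > 7400 nM in this assay, which is a limit of the assay. No step can be read from compound 1 or compound 2 to compound 3, as all three sit at the same limit: the limit of > 7400 nM in this assay, at which 3 of the 3 values shown sit. The compounds shown leave open what number any of them would give and whether phenyl to 4-fluorophenyl shifts it.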